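A few compounds are considered here, and "the series" means these few. Any claim that something is new, unique, unknown or untested is made for them only; others in the source may bear on it.

In a functional assay on HEK293 cells (Homo sapiens) for cytotoxicity (on this read-out lower numbers stand for higher toxicity in this test and higher numbers for lower toxicity in this test), compound 1 (`COc1ccc([C@H]2CC(=O)N(c3cccc(N(C)C)c3)C2)cc1OC1CCCC1`) gives > 10000 nM, which is a limit of the assay. Compound 2 (`COc1ccc([C@H]2CC(=O)N(c3ccccc3N)C2)cc1OC1CCCC1`) gives > 10000 nM, again a limit and not a number, so its position in the series cannot be ranked. Compound 3 (`COc1ccc([C@H]2CC(=O)N(c3ccccc3C#N)C2)cc1OC1CCCC1`) carries cyano in place of amino on an aromatic carbon, ortho to a large group: cyano in place of amino on an aromatic carbon. Among the measured compounds shown here, the one measured step that bears on this change is a step that the two limits leave unreadable from compound 1 to compound 2, and it supplies no size to carry over. The remaining evidence is the limit of > 10000 nM in this assay, at which 2 of the 2 values shown sit. With no readable step in the series, no step beyond the scatter is expected in this assay, and no direction can be assigned. The expected change is a step that the limit leaves unreadable from compound 2 to compound 3. For compound 3 the estimated value is 15000 nM, with an expected range from 6000 nM to 40000 nM.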

Compound 3, half-maximal cytotoxic concentration: > 10000 nM
Compound 3 ended at the assay's limit (the forecaster's own chance of this, stated with the estimate: 85%); the middle value does not contradict the limit.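

In this assay compound 1, compound 2 and compound 3 all sit at a limit, so no step among them can be read: the limit of > 10000 nM in this assay, at which 3 of the 3 values shown sit.

The compounds shown leave open whether 2-aminophenyl, 2-cyanophenyl and 3-(dimethylamino)phenyl differ at all in this assay, and which change to the shared core, if any, would give a readable value.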